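The compounds below may be only part of what the source reports. "The series", "measured", "known", "first", "only" and "open" are said of these compounds alone.

Compound 1 `CC1=CC[C@@]2(CC1)C(C(C)C)=CC[C@@H]2CO`, compound 2 `CC(C)C1=CC[C@H](C(=O)O)[C@@]12C=CC(=O)CC2` and compound 3 `CC(C)(C)[Si](C)(C)OCCC1=CC[C@H](CO)[C@@]12C=CC(=O)CC2` were examined in an ADME assay on BJ cells (Homo sapiens) for cytotoxicity, with a stated time of 72 h; on this read-out lower numbers stand for an effect already at smaller amounts and higher numbers for an effect only at larger amounts of compound. In this assay compound 1 gives > 90000 nM, which is a limit of the assay rather than a number. Compound 2 gives > 90000 nM, again a limit. Compound 3 gives > 90000 nM, also a limit. Compound 2 thus stands at the limit of > 90000 nM in this assay, at which 3 of the 3 values shown sit, with no number to compare against. Compound 4 `CC(C)C1=CC[C@H](C(N)=O)[C@@]12C=CC(=O)CC2` has not yet been measured in this assay; it differs from compound 2 by amino in place of hydroxy on a carbonyl carbon. Going by the values given here, no step between measured compounds is available to guide the expectation, so no shift beyond the usual scatter is expected. Compound 4 is therefore expected to give 90000 nM, within 30000 nM to 200000 nM. The implied step, a number no higher from compound 2 to compound 4 (the limit leaves the size open), is expected to stay within the scatter.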

Compound 4, half-maximal effective concentration: > 90000 nM
Compound 4 was reported as a limit; the forecaster's own chance of this, stated with the estimate: 85%; the middle value lies on the limit itself.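

Compound 2 and compound 4 are both reported only as limits, so no step can be read between them. The compounds shown leave open what number, if any, each would reach in this assay, and what carboxy to carbamoyl changes there: the limit of > 90000 nM in this assay, at which 4 of the 4 values shown sit.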